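Replacing a Pyridine Ring by Thiophene on a Shared Core

The source may hold more compounds than are shown below. What is called first, only, known or untested is meant among the compounds shown, and "the series" means these compounds.

Of the compounds shown here, three sharing one core have been tested in an assay on isolated protein for inhibition of DNA topoisomerase 1 (Homo sapiens), with a stated time of 30 min, tested at 100 uM; a lower number here means a weaker effect, a higher number a stronger effect of the compound at the concentration tested. Compound 1 `Oc1cccc(-c2cc(-c3ccncc3)nc(-c3cccc(Cl)c3)c2)c1` gives 0% and compound 3 `Oc1cccc(-c2cc(-c3cccnc3)nc(-c3ccccc3Cl)c2)c1` gives 0%; these two are level at the digits shown and together sit lowest of the three. Compound 2 `Oc1cccc(-c2cc(-c3ccc(Cl)cc3)nc(-c3cccs3)c2)c1` gives 15.1%, a number that lies beyond the scatter above compound 1. The next compound, compound 4 `Oc1cccc(-c2cc(-c3ccsc3)nc(-c3cccc(Cl)c3)c2)c1`, has not been measured. Compared with compound 1 it carries thiophen-3-yl in place of pyridin-4-yl on an aromatic carbon. For the measured compounds named here, no measured pair shows this exchange, so its effect is unknown; the read-out of compound 2 leaves room for a modest rise. A small upward step a number 8 percentage points higher from compound 1 to compound 4 (within the scatter) is expected, staying within or near the scatter. Compound 4 is estimated at 8%, between 0% and 25%.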

Compound 4, a percentage reported as inhibition, at one concentration (the size of the read-out at that concentration, not a potency): 26.2%
For compound 4 the middle estimate is 18.2 percentage points below the measured one; measured number outside the range, above it.
By their numbers in this assay, from the lowest: compounds 1 and 3 (each within the scatter of the next); then compound 2; then compound 4.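

Swapping pyridin-4-yl for thiophen-3-yl, with the 3-chlorophenyl and 3-hydroxyphenyl groups kept, gives the first comparison in this assay that changes only one place: a number 26.2 percentage points higher from compound 1 to compound 4 (beyond the scatter). The read-out therefore depends on which aromatic ring sits at this position, at least in this one pair. Nothing available explains the rise. The compounds shown leave open whether a furan-3-yl ring, a plain phenyl ring or a ring carrying a carboxylic acid would behave like thiophen-3-yl here, and whether the same swap would give a similar step with another chlorophenyl arrangement.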